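A few compounds are considered here, and "the series" means these few. Any claim that something is new, unique, unknown or untested is made for them only; others in the source may bear on it.

Measured compounds in a functional assay on the whole organism (strain CD-1) with Mus musculus as the target, with a stated time of 2 h; a higher number here means that more compound is needed for the effect, a lower number that less compound is needed:
Compound 1, `CC1(c2ccccc2)CC(=O)N(CC(=O)N2CCN(c3ccccc3Cl)CC2)C1=O`, compound 1 gives 100 mg/kg.
Compound 2, `CC1(c2ccccc2)CC(=O)N(CC(=O)N2CCN(c3ccc(F)cc3)CC2)C1=O`, compound 2 gives "not active" (no number reported).
Compound 3, `COc1cccc(N2CCN(C(=O)CN3C(=O)CC(C)(c4ccccc4)C3=O)CC2)c1`, compound 3 gives "not active" (no number reported).

Compound 2 stands without a single number in this assay: its entry is a report of no activity, and compound 3 shares that standing, with one entry of the same kind. Only compound 1 carries a numeric minimum effective dose in this assay, and it is a high one. For the measured compounds named here, no step between two numerically measured compounds is available, so nothing can be said about how the amine substituent on the ring shifts the dose.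

The unmeasured compound 4, `CC1(c2ccccc2)CC(=O)N(CC(=O)N2CCN(c3ccc(Cl)c(Cl)c3)CC2)C1=O`, differs from compound 2 in one place: 3,4-dichlorophenyl in place of 4-fluorophenyl on an amine nitrogen in a ring. With compound 2 reported as not active, and compound 3 likewise, no step size in this assay can be stated with confidence; the expectation is that compound 4 either stays without a number or, if a number is found, lands near the high dose seen for compound 1.

Compound 4 is therefore estimated at 300 mg/kg, within a range from 100 mg/kg to 1000 mg/kg, with a substantial chance that no number is reported at all.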

Compound 4, minimum effective dose: "not active" (no number reported)
Nothing numeric was reported for compound 4, and the estimate cannot be compared.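

In this assay, for the compounds shown here, compound 4, like compound 2, is reported as not active, so no step between the two can be read. With compound 1 at 100 mg/kg as the only numeric dose, the compounds shown leave open how the aryl group on the amine nitrogen shifts the dose. No evidence bears on this result.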